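A few compounds are considered here, and "the series" means these few. Any claim that something is new, unique, unknown or untested is made for them only; others in the source may bear on it.

In a functional assay on A549 cells (Homo sapiens) for inhibition, read by MTT assay, with a stated time of 48 h (a lower number here means a stronger inhibitor, a higher number a weaker inhibitor), compound 3 (`COc1ccc(C(c2c[nH]c3ccc(Br)cc23)c2c[nH]c3ccc(Br)cc23)cc1OC`) gives 12000 nM. Compound 1 (`COc1ccc(C(c2c[nH]c3ccc(Br)cc23)c2c[nH]c3ccc(Br)cc23)cc1`) gives 10000 nM, within the scatter of that number, while compound 2 (`COc1cccc(C(c2c[nH]c3ccc(Br)cc23)c2c[nH]c3ccc(Br)cc23)c1OC`) gives a much higher 100000 nM. Compound 4 (`Clc1ccc(C(c2c[nH]c3ccc(Br)cc23)c2c[nH]c3ccc(Br)cc23)cc1`) has 4-chlorophenyl in place of 3,4-dimethoxyphenyl on a saturated chain carbon bound to two aromatic carbons. Among the measured compounds shown here, no measured compound carries 4-chlorophenyl, so the evidence is indirect. Methoxy in place of hydrogen gave only a 1.2-fold higher number from compound 1 to compound 3 (0.08 log units; within the scatter), whereas the 2,3-dimethoxyphenyl group accounts for the large 8.3-fold lower number from compound 2 to compound 3 (0.92 log units; beyond the scatter). Compound 4 lacks that group, so no step beyond the scatter is expected in this assay. The expected step is a 1.2-fold lower number from compound 3 to compound 4 (0.08 log units; within the scatter). Compound 4 is estimated at 10000 nM, within a range of 4000 nM to 30000 nM.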

Compound 4, half-maximal inhibitory concentration: 8500 nM
Compound 4: middle estimate off by 1.2-fold (0.07 log units), on the high side, and the stated range covers the measured number.
By their numbers in this assay, from the lowest: compounds 4, 1 and 3 (each within the scatter of the next); then compound 2.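

A chlorine-bearing ring works at this saturated chain carbon: in this assay the change to 4-chlorophenyl gives (a 1.4-fold lower number from compound 3 to compound 4 (0.15 log units; within the scatter)) and, with chloro in place of methoxy, (a 1.2-fold lower number from compound 1 to compound 4 (0.07 log units; within the scatter)), so neither oxygen-bearing group is needed to keep this level. The 2,3-dimethoxyphenyl group alone stands apart, with (a 12-fold lower number from compound 2 to compound 4 (1.07 log units; beyond the scatter)). No measurement here accounts for these differences. On these data alone, whether an unsubstituted phenyl ring, or a phenyl ring carrying an amine or a carboxylic acid, would hold the same level remains open.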